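The source may hold more compounds than are shown below. What is called first, only, known or untested is meant among the compounds shown, and "the series" means these compounds.

Of the compounds shown here, two from this series have been measured in an in vitro assay on HEK385-7 cells for displacement of a labelled ligand from prostaglandin D2 receptor 2 (Homo sapiens); on this read-out lower numbers stand for stronger inhibition and higher numbers for weaker inhibition. Compound 1 `O=C(O)Cc1sc(C(c2ccc(F)cc2)c2ccc(F)cc2)nc1-c1cc(F)cc(F)c1` gives 35 nM in this assay, and compound 2 `O=C(O)Cc1sc(C(c2ccccc2)c2ccc(Cl)cc2)nc1-c1ccc(Cl)cc1` gives 45 nM in this assay. Compound 1 holds the lower of the two numbers, but its gap to compound 2 lies within the scatter, so the two compounds cannot be told apart on these data. The unmeasured compound 3 `N#Cc1ccc(-c2nc(C(c3ccc(F)cc3)c3ccc(F)cc3)sc2CC(=O)O)cc1` differs from compound 1 in one place: 4-cyanophenyl in place of 3,5-difluorophenyl on an aromatic carbon. For the measured compounds named here, no measured pair shows this change, so its effect is unknown. Given that the only reference for compound 3 is compound 1 with 35 nM, the step of a 1.4-fold higher number from compound 1 to compound 3 (0.15 log units; within the scatter) is expected to be small and not clearly beyond the scatter, with a slight lean towards a higher number. Compound 3 is therefore estimated at 50 nM in this assay, within a range from 15 nM to 170 nM.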

Compound 3, half-maximal inhibitory concentration: 150 nM
Beside the measured number, compound 3's estimate is 3.0-fold (0.48 log units) below it; the range from low to high includes it.
By their numbers in this assay, from the lowest: compounds 1 and 2 (each within the scatter of the next); then compound 3.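

In this assay, the aromatic carbon next to the ring nitrogen proves sensitive to the group it carries: 4-cyanophenyl in place of 3,5-difluorophenyl gives a 4.3-fold higher number from compound 1 to compound 3 (0.63 log units; beyond the scatter) and this modest step lies beyond the scatter. For the compounds shown here, the earlier compounds offered no measured step at this position, so this is the first reading of how inhibition responds to a change there, and here the change weakens it. Nothing in the available data accounts for the step.

The compounds shown leave open whether the weaker inhibition goes with the nitrile itself or with the loss of the two fluorines, and a single pair cannot separate these. They also leave open how a methoxy group or a carboxamide in place of the nitrile would read out at this position.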